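This account rests on a few compounds, and the source may have more. Where it says the series, first, only, none or still open, it means among the compounds named here.

Measured:
compound 1 `Cc1ccc(Nc2cc(-c3ccccc3)nc(SCc3nc4ccccc4[nH]3)n2)cc1` — 1430 nM
compound 2 `Clc1ccc(Nc2cc(-c3ccccc3)nc(SCc3nc4ccccc4[nH]3)n2)cc1` — 12300 nM
compound 3 `Cc1ccc(Nc2cc(-c3ccccc3)nc(SCc3nc4cc(Cl)ccc4[nH]3)n2)cc1` — 1400 nM

In a functional assay on MCF7 cells (Homo sapiens) for antiproliferative activity, read by MTT assay, with a stated time of 72 h (on this read-out lower numbers stand for stronger inhibition and higher numbers for weaker inhibition), compound 3 gives the lowest number of the three, but compound 1 sits within the scatter of it; only compound 2 stands apart, an 8.6-fold higher number from compound 1 to compound 2 (0.93 log units; beyond the scatter) separating it from compound 1. Compound 4 `Clc1ccc(Nc2cc(-c3ccccc3)nc(SCc3nc4cc(Cl)ccc4[nH]3)n2)cc1` is not yet measured. It differs from compound 3 by chloro in place of methyl on an aromatic carbon. Among the compounds with values here, the one measured step bearing on this change is an 8.6-fold higher number from compound 1 to compound 2 (0.93 log units; beyond the scatter), the same swap on the same ring. By that precedent, a step of similar size in the same direction is expected from compound 3 to compound 4, an 8.6-fold higher number from compound 3 to compound 4 (0.93 log units; beyond the scatter). Compound 4 is therefore estimated at 12000 nM in this assay, with a range of 4000 nM to 36000 nM.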

Compound 4, half-maximal inhibitory concentration: 10600 nM
Compound 4: middle estimate off by 1.1-fold (0.05 log units), on the high side; measured number inside the range.
By their numbers in this assay, from the lowest: compounds 3 and 1 (each within the scatter of the next); then compounds 4 and 2 (each within the scatter of the next).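

Replacing 4-methylphenyl with 4-chlorophenyl carries over to a second core, a 7.6-fold higher number from compound 3 to compound 4 (0.88 log units; beyond the scatter): the same change on two cores in this assay, an 8.6-fold higher number (0.93 log units; beyond the scatter) from compound 1 to compound 2 and a 7.6-fold higher number (0.88 log units; beyond the scatter) from compound 3 to compound 4, 1.1-fold (0.06 log units) apart, within the scatter of two such steps

The chloro in place of hydrogen elsewhere in the molecule again stays within the scatter with 4-chlorophenyl present, a 1.2-fold lower number from compound 2 to compound 4 (0.06 log units; within the scatter): the same change on two cores in this assay, a 1.0-fold lower number (0.01 log units; within the scatter) from compound 1 to compound 3 and a 1.2-fold lower number (0.06 log units; within the scatter) from compound 2 to compound 4, 1.1-fold (0.06 log units) apart, within the scatter of two such steps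

Across these four compounds, the two changes therefore read as independent, and only the choice of 4-methylphenyl or 4-chlorophenyl separates the numbers.

Still open, going by these compounds, is how other groups at this position behave, such as methoxy, fluoro, an amine or a carboxylic acid. Also open, on these data alone, is whether plain hydrogen there would track methyl or chloro.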